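Pyridinyl Gives Way to Methylthiazolyl on a Saturated Ring Carbon

A few compounds are considered here, and "the series" means these few. Any claim that something is new, unique, unknown or untested is made for them only; others in the source may bear on it.

Three compounds have been measured in a functional assay for agonist activity at G protein-coupled receptor 88 (Homo sapiens), read by HTRF and cAMP accumulation; a lower number here means that less compound is needed, a higher number that more compound is needed for the effect:
compound 1, `CC[C@H](C)[C@H](N)CN(C(=O)[C@@H]1C[C@H]1c1ccc(F)cc1)c1ccc(-c2ccccc2)cc1`, gives 600 nM;
compound 2, `CC[C@H](C)[C@H](N)CN(C(=O)[C@@H]1C[C@H]1c1ccccc1F)c1ccc(-c2ccccc2)cc1`, gives 650 nM;
compound 3, `CC[C@H](C)[C@H](N)CN(C(=O)[C@@H]1C[C@H]1c1ccncc1)c1ccc(-c2ccccc2)cc1`, gives 1500 nM.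

Compound 3 has the highest number of the three. The steps of a 2.5-fold higher number from compound 1 to compound 3 (0.40 log units; beyond the scatter) and a 2.3-fold higher number from compound 2 to compound 3 (0.36 log units; beyond the scatter) are both modest, while a 1.1-fold higher number from compound 1 to compound 2 (0.03 log units; within the scatter) lies within the scatter. Compound 4 is `CC[C@H](C)[C@H](N)CN(C(=O)[C@@H]1C[C@H]1c1csc(C)n1)c1ccc(-c2ccccc2)cc1`; the change from compound 3 is 2-methyl-1,3-thiazol-4-yl in place of pyridin-4-yl on a saturated ring carbon. For the measured compounds named here, no measured step exchanges one heteroaryl group for another on this saturated ring carbon, so the earlier steps bear only loosely on it; they show that changing the aromatic group there moved the number modestly at most. Compound 4 is therefore expected to stay near compound 3, with a 1.2-fold lower number from compound 3 to compound 4 (0.06 log units; within the scatter) not beyond the scatter. The estimate for compound 4 is 1300 nM, ranging from 500 nM to 3500 nM.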

Compound 4, half-maximal effective concentration: 1500 nM
The estimate for compound 4 lay 1.2-fold (0.06 log units) below the measured number; low and high end bracket the measured number.
By their numbers in this assay, from the lowest: compounds 1 and 2 (each within the scatter of the next); then compounds 3 and 4 (each within the scatter of the next).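

For the compounds shown here, the first exchange of one heteroaryl group for another on this saturated ring carbon, a five-membered ring with sulfur for a six-membered one, leaves the two compounds level (no change at the digits printed from compound 3 to compound 4 (within the scatter)). The higher numbers seen for compound 3 are thus not confined to pyridin-4-yl: 2-methyl-1,3-thiazol-4-yl also stands modestly above both fluorophenyl compounds (a 2.3-fold higher number from compound 2 to compound 4 (0.36 log units; beyond the scatter); a 2.5-fold higher number from compound 1 to compound 4 (0.40 log units; beyond the scatter)). No measurement given here accounts for this match. Still open, going by these compounds, is how an amine or a carboxylic acid on the aromatic group would read, and whether the methyl on the 2-methyl-1,3-thiazol-4-yl group affects the number.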